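Substituents on the amide-linked ring and cell toxicity

This account rests on a few compounds, and the source may have more. Where it says the series, first, only, none or still open, it means among the compounds named here.

Of the compounds shown here, three have been measured in an ADME assay on MT4 cells (Homo sapiens) for cytotoxicity, read by MTT assay, with a stated time of 5 days; on this read-out lower numbers stand for higher toxicity in this test and higher numbers for lower toxicity in this test. Compound 1 `O=C(CSc1snnc1-c1ccc(Br)cc1Br)Nc1ccccc1[N+](=O)[O-]` gives > 235000 nM, which is a limit of the assay rather than a number. Compound 2 `O=C(CSc1snnc1-c1ccc(Br)cc1Br)Nc1ccccc1Cl` gives > 240000 nM, again a limit of the assay. Compound 3 `O=C(CSc1snnc1-c1ccc(Br)cc1Br)Nc1ccccc1` gives 24800 nM.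

For the measured compounds named here, compound 3 therefore stands alone: it is the only compound of the three with an actual number, while compounds 1 and 2 sit at limits. Two measured steps lead to it. In an at least 9.4-fold lower number from compound 1 to compound 3 (0.97 log units; beyond the scatter) the nitro group is removed from the amide-linked ring, and in an at least 9.6-fold lower number from compound 2 to compound 3 (0.98 log units; beyond the scatter) the chloro group is removed; both steps lower the number, that is, they increase toxicity. The step that the two limits leave unreadable from compound 1 to compound 2 cannot be sized.

Compound 4 `Cc1ccc(NC(=O)CSc2snnc2-c2ccc(Br)cc2Br)c(Br)c1` differs from compound 3 by 2-bromo-4-methylphenyl in place of phenyl on an amide-type nitrogen. This goes in the opposite direction to the two readable steps: substituents are added to the amide-linked ring instead of removed. A step upward is therefore expected, of the order of a 6.0-fold higher number from compound 3 to compound 4 (0.78 log units; beyond the scatter), with a fair chance that only a limit is reported. For compound 4 the estimate is 150000 nM, with a range from 40000 nM to 400000 nM.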

Compound 4, half-maximal cytotoxic concentration: > 216000 nM
Compound 4: only a limit was reported; the forecaster's own chance of this, stated with the estimate: 45%; middle value at least 1.4-fold (0.15 log units) from the limit.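

In this assay, 2-bromo-4-methylphenyl in place of phenyl on the amide-type nitrogen gives an at least 8.7-fold higher number from compound 3 to compound 4 (0.94 log units; beyond the scatter), which adds a third substituted ring to the two already seen and brings in a bromo and a methyl group rather than a nitro or a chloro group. Across the four compounds, the plain phenyl ring of compound 3 gives the only actual number, and all three substituted rings end at limits, with no compound shown going against this. Compound 4 also rests on a limit of the assay, not on a number: the limit of > 216000 nM in this assay, at which 1 of the 4 values shown sits.

The steps from compound 1 and from compound 2 to compound 4 join limit to limit and cannot be read, and the three substituted rings therefore cannot be put in order. Also open, going by these compounds, is whether the bromo or the methyl group alone would account for the step from the plain phenyl ring, and whether a ring carrying an amine or a carboxylic acid would give an actual number or another limit.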